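A Cage Amine Series at the D1B Receptor

The source may report more compounds than this note shows. Statements on the series, on what has been measured and on what is new or still open speak of the compounds shown alone.

Three compounds share a cage-like saturated core carrying an amine, and only one of them has yielded a number in an assay on isolated protein for inhibition of D(1B) dopamine receptor (Homo sapiens); on this read-out higher numbers stand for weaker inhibition and lower numbers for stronger inhibition. Compound 1, `Fc1cccc(CCCN[C@H]2C3C4CC5C6C4CC3C6C52)c1`, has a value recorded as "not determined" (no result reported). Compound 2, `COc1cc(CN[C@H]2C3C4CC5C6C4CC3C6C52)cc(OC)c1OC`, reaches only the limit of the assay, > 10000 nM, which is a limit and not a number. This is the point described by the limit of > 10000 nM in this assay, at which 1 of the 3 values shown sits. Compound 3, `CN(Cc1ccccc1)[C@H]1C2C3CC4C2C(=O)C2C4C3C21`, carries a methyl and a benzyl group on the amine nitrogen and a carbonyl on the core; its entry in this assay reads "not determined" (no result reported). Compound 3 therefore stands nowhere on the numbers shown; neither it nor compound 1 has a single number.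

Compound 4, `CN(Cc1cccnc1)[C@H]1C2C3CC4C2C(=O)C2C4C3C21`, differs from compound 3 in one place: pyridin-3-yl in place of phenyl on a saturated chain carbon bound to an amine nitrogen. No measured step between any two of these compounds exists, so the size and direction of this change in this assay cannot be read from the data. Against that background, and with the only reported value in the series sitting at the limit, compound 4 is expected to give roughly 10000 nM in this assay, within a range from 2000 nM to 50000 nM, with a real chance that only a limit is reported.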

Compound 4, inhibition constant: > 10000 nM
Compound 4 gave a limit, no number (the forecaster's own chance of this, stated with the estimate: 65%); the middle value lies on the limit itself.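

In this assay compound 4 gives > 10000 nM, which is a limit and not a number. Among the compounds shown here, compound 3 has no number to set against it, so no step from compound 3 to compound 4 can be read. The compounds shown leave open how strongly any of them inhibits this receptor, since the only results reported stop at one limit: the limit of > 10000 nM in this assay, at which 2 of the 4 values shown sit.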